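A few compounds are considered here, and "the series" means these few. Any claim that something is new, unique, unknown or untested is made for them only; others in the source may bear on it.

Compound 1 `COc1cc(OC)c2c(c1)C(C(O)c1ccc(OCCOc3ccccc3)cc1)OC2=O`: > 10000 nM, a limit
Compound 2 `C=CCCOc1ccc(C(O)C2OC(=O)c3c(OC)cc(OC)cc32)cc1`: 1330 nM

For the measured compounds named here, in a functional assay on RAW264.7 cells (Mus musculus) for inhibition, read by Griess assay, with stated times of 1 h and 24 h (on this read-out lower numbers stand for stronger inhibition and higher numbers for weaker inhibition), compound 2 holds the only actual number, 1330 nM. Compound 1 is recorded only as a limit, > 10000 nM.

Compound 3 `COc1cc(OC)c2c(c1)C(C(O)c1ccc(OCc3ccc(OC(F)F)cc3)cc1)OC2=O` has not yet been measured. Its difference from compound 2 is 4-(difluoromethoxy)phenyl in place of allyl on a saturated chain carbon bound to an oxygen on an aromatic ring.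

Going by the values given here, one measured step bears on this change: an at least 7.5-fold lower number from compound 1 to compound 2 (0.87 log units; beyond the scatter). That step put vinyl in place of phenoxy, whereas the new change brings an aromatic ring back into the chain. Among the compounds with values here, this single step, which rests on a limit, is the only guide, and the two changes are not the same. A higher number is therefore expected in this assay, of moderate size and beyond the scatter.

The expected step is a 3.8-fold higher number from compound 2 to compound 3 (0.58 log units; beyond the scatter).

For compound 3 the estimated value is 5000 nM, with an expected range from 1500 nM to 15000 nM.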

Compound 3, half-maximal inhibitory concentration: 5030 nM
For compound 3 the middle estimate is 1.0-fold (0.00 log units) below the measured one; the measured number falls inside the stated range.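

In this assay, compound 3 shows that a group carrying an aromatic ring on the saturated chain carbon bound to an oxygen on an aromatic ring can still give a measurable number, although 4-(difluoromethoxy)phenyl in place of allyl weakens inhibition, with a 3.8-fold higher number from compound 2 to compound 3 (0.58 log units; beyond the scatter). Set against the phenoxymethyl group at the same place, 4-(difluoromethoxy)phenyl gives an at least 1.9-fold lower number from compound 1 to compound 3 (0.29 log units; that floor lies within the scatter), so compound 3 cannot be placed clearly ahead of compound 1, and an aromatic ring in this side chain does not by itself separate the two. The figure for compound 1 is a limit and not a number: the limit of > 10000 nM in this assay, at which 1 of the 3 values shown sits.

The compounds shown leave open whether the weaker inhibition of compound 3 relative to compound 2 goes with the ring itself or with the difluoromethoxy group on it, which a plain benzyl group at this place would help to separate. Also open, from the compounds shown here alone, is whether the double bond of the but-3-en-1-yl chain matters, a question that a saturated butyl chain would address.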